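Methylsulfonyl for methylsulfanyl on a trifluoromethyl-bearing core

The source may hold more compounds than are shown below. What is called first, only, known or untested is meant among the compounds shown, and "the series" means these compounds.

Compound 1 `CSc1ccc(C)cc1NCC1=NCCN1` gives 17.4 nM in an assay for binding affinity to Alpha-1D adrenergic receptor (Homo sapiens), read by radioligand binding; on this read-out higher numbers stand for weaker inhibition and lower numbers for stronger inhibition. Compound 2 `Cc1ccc(S(C)(=O)=O)c(NCC2=NCCN2)c1` gives 4790 nM in this assay, and the change methylsulfonyl in place of methylsulfanyl on an aromatic carbon made the step of a 280-fold higher number from compound 1 to compound 2 (2.44 log units; beyond the scatter). Compound 3 `CSc1ccc(C(F)(F)F)cc1NCC1=NCCN1` gives 479 nM in this assay; it differs from compound 1 by trifluoromethyl in place of methyl on an aromatic carbon, and the step was a 28-fold higher number from compound 1 to compound 3 (1.44 log units; beyond the scatter). Compound 4 `CS(=O)(=O)c1ccc(C(F)(F)F)cc1NCC1=NCCN1` is not yet measured. It differs from compound 3 by methylsulfonyl in place of methylsulfanyl on an aromatic carbon, the same kind of change as from compound 1 to compound 2, though here the place is para to a trifluoromethyl group rather than para to a methyl group. He expects a step of a 130-fold higher number from compound 3 to compound 4 (2.10 log units; beyond the scatter) in this assay for compound 4, since the earlier step of a 280-fold higher number from compound 1 to compound 2 (2.44 log units; beyond the scatter) was large and the core of compound 3 already stands at 479 nM. His estimate for compound 4 is 60000 nM, between 10000 nM and 300000 nM.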

Compound 4, inhibition constant: < 15900 nM
Compound 4 ended at the assay's limit; the forecaster's own chance of this, stated with the estimate: 35%; middle value at least 3.7-fold (0.57 log units) away from the limit.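

In this assay compound 4 gives < 15900 nM, a limit of the assay and not a number. Its steps from compound 3 and compound 2 therefore cannot be read. The compounds shown leave open how large the change from methylsulfanyl to methylsulfonyl is when trifluoromethyl is present.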